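This account rests on a few compounds, and the source may have more. Where it says the series, first, only, none or still open, it means among the compounds named here.

Among the compounds with values here, compound 1 `COc1ccc(C2CC(Nc3nc4ccc(C)cc4s3)=NN2C(C)=O)cc1O` gives 75.6 umol/kg in a functional assay on the whole organism (strain albino) with Mus musculus as the target, with a stated time of 0.5 h; on this read-out lower numbers stand for an effect already at smaller amounts and higher numbers for an effect only at larger amounts of compound; it is the only compound of the series with a number on this read-out, since compound 2 `COc1ccc(C2CC(Nc3nc4ccccc4s3)=NN2C(C)=O)cc1O` has the entry "not determined" (no result reported) in this assay. Compound 3 `CC(=O)N1N=C(Nc2nc3ccc(C)cc3s2)CC1c1ccc(Cl)cc1` differs from compound 1 in one place: 4-chlorophenyl in place of 3-hydroxy-4-methoxyphenyl on a saturated ring carbon. Within the data shown here, no measured pair shares this change, so the step has no precedent; a step of modest size is expected, in either direction, not far beyond the usual scatter. Compound 3 is expected to give about 70 umol/kg in this assay, within 30 umol/kg to 160 umol/kg. This estimate means a step of a 1.1-fold lower number from compound 1 to compound 3 (0.03 log units; within the scatter).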

Compound 3, dose for half-maximal effect: 27.5 umol/kg
Compound 3: the middle estimate sits 2.5-fold (0.41 log units) above what was measured, outside the stated range (below it).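

At the saturated ring carbon, the 3-hydroxy-4-methoxyphenyl group is not needed for an effect in this assay: 4-chlorophenyl in its place gives a 2.7-fold lower number from compound 1 to compound 3 (0.44 log units; beyond the scatter). The entering group has neither a hydrogen-bond donor nor an acceptor, yet the number falls in this single pair. No measurement on the cause of this step is available.

Still open, from the compounds shown here alone, is whether the chlorine or the loss of the hydroxy and methoxy groups carries the step. Unsubstituted phenyl, 4-methoxyphenyl or 4-aminophenyl on this carbon would help separate these.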